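The source may hold more compounds than are shown below. What is called first, only, known or untested is meant among the compounds shown, and "the series" means these compounds.

Three compounds have been measured in a functional assay on QGY7701 cells (Homo sapiens) for cytotoxicity, read by MTT assay, with a stated time of 24 h; on this read-out higher numbers stand for weaker inhibition and lower numbers for stronger inhibition:

compound 1 `C=CC1=C(C(=O)NCc2ccccc2)C(c2ccc(OC)c(OC)c2)OC1` — > 100000 nM
compound 2 `C=CC1=C(C(=O)NCc2ccccc2)C(c2ccc(OC)cc2)OC1` — > 100000 nM
compound 3 `C=CC1=C(C(=O)NCc2ccc(C)cc2)C(c2ccc(F)cc2)OC1` — 62100 nM

Compound 1 stands at a limit: in this assay compound 1 gives > 100000 nM, which is a limit of the assay and not a number. Compound 2 likewise gives > 100000 nM, also a limit. Compound 3 gives a number, 62100 nM, the only one among the three. Among the compounds with values here, the single one-point step, a step that the two limits leave unreadable from compound 1 to compound 2, runs between two limits and cannot be sized, as the limit of > 100000 nM in this assay, at which 2 of the 3 values shown sit, shows.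

Compound 4 `C=CC1=C(C(=O)NC2CCCCC2)C(c2ccc(OC)c(OC)c2)OC1` differs from compound 1 by cyclohexyl in place of benzyl on an amide-type nitrogen. Within the data shown here, no measured step touches this change, and compound 1 itself offers only a limit, so the data give no direction for it. Compound 4 is therefore expected to stay near that limit, with a step that the limit leaves unreadable from compound 1 to compound 4 expected to be no step beyond the scatter. The estimate for compound 4 is 150000 nM, between 40000 nM and 600000 nM.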

Compound 4, half-maximal inhibitory concentration: 7490 nM
The estimate for compound 4 lay 20-fold (1.30 log units) above the measured number; measured number outside the range, below it.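

In this assay, within the data shown here, cyclohexyl in place of benzyl on an amide-type nitrogen gives an at least 13-fold lower number from compound 1 to compound 4 (1.12 log units; beyond the scatter), the first step that can be read. Among these compounds, it shows that the group on this nitrogen can move the read-out beyond the scatter while the rest of compound 1 stays unchanged, something the earlier compounds, with their benzyl-type groups there, could not show. That step is only a bound and not an exact size, because compound 1 stands at a limit of the assay: the limit of > 100000 nM in this assay, at which 2 of the 4 values shown sit.

From the compounds shown here alone, whether a smaller ring such as cyclopentyl or an open chain such as n-hexyl on this nitrogen would give a similarly low number remains open. Also open, going by these compounds, is whether cyclohexyl has the same effect when carried by the core of compound 2 or compound 3.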